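Shortening an Ester Chain into a Cyclohexyl Ring

The compounds below may be only part of what the source reports. "The series", "measured", "known", "first", "only" and "open" are said of these compounds alone.

Measured so far:
- compound 1 `CCCCNC(=O)c1cc(NC(=O)c2cnc(Cl)nc2C(F)(F)F)cc(C(F)(F)F)c1`: in an assay on Jurkat cells for inhibition of cyclic AMP-dependent transcription factor ATF-1 (Homo sapiens) (on this read-out lower numbers stand for stronger inhibition and higher numbers for weaker inhibition), compound 1 is reported only as a limit of the assay, > 10000 nM.
- compound 2 `CCOC(=O)c1cc(NC(=O)c2cnc(Cl)nc2C(F)(F)F)cc(C(F)(F)F)c1`: compound 2 gives 150 nM.
- compound 3 `CCCCCCCCOC(=O)c1cc(NC(=O)c2cnc(Cl)nc2C(F)(F)F)cc(C(F)(F)F)c1`: compound 3 gives 1200 nM.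

All three compounds share the same core and differ only in the group attached to one carbonyl carbon. Compound 1, with a butylamino group there, sits at the limit (the limit of > 10000 nM in this assay, at which 1 of the 3 values shown sits). Exchanging that group for ethoxy gives an at least 66-fold lower number from compound 1 to compound 2 (1.82 log units; beyond the scatter), and exchanging it for octyloxy gives an at least 8.3-fold lower number from compound 1 to compound 3 (0.92 log units; beyond the scatter). Of the two actual numbers, compound 3 stands highest, separated from compound 2 by an 8.0-fold higher number from compound 2 to compound 3 (0.90 log units; beyond the scatter).

Compound 4 `O=C(OC1CCCCC1)c1cc(NC(=O)c2cnc(Cl)nc2C(F)(F)F)cc(C(F)(F)F)c1` is the next member. It differs from compound 3 by cyclohexyl in place of octyl on an oxygen next to a carbonyl group. For the measured compounds named here, the one measured step that alters the ester side, an 8.0-fold higher number from compound 2 to compound 3 (0.90 log units; beyond the scatter), shows that a longer chain on this oxygen raised the number. Cyclohexyl is counted with fewer carbons than octyl, though it is a ring rather than a chain, so a number between those of compound 2 and compound 3 is expected, meaning a step of a 2.4-fold lower number from compound 3 to compound 4 (0.38 log units; beyond the scatter). Compound 4 is therefore estimated at 500 nM, within a range from 150 nM to 2000 nM.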

Compound 4, half-maximal inhibitory concentration: 1200 nM
Estimate against measurement, compound 4: 2.4-fold (0.38 log units) below; measured number inside the range.
By their numbers in this assay, from the lowest: compound 2; then compounds 3 and 4 (each within the scatter of the next). At a limit, above all of these: compound 1.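

In this assay, cyclohexyl on this oxygen cannot be told apart from octyl, no change at the digits printed from compound 3 to compound 4 (within the scatter), even though it has fewer carbons and is closed into a ring. The trend suggested by compound 2 and compound 3, a higher number with more carbons on the ester oxygen, therefore does not hold as a simple count: compound 4 goes against it, and the ring sits level with the long chain rather than partway towards ethyl, an 8.0-fold higher number from compound 2 to compound 4 (0.90 log units; beyond the scatter). Compound 4 also stands clear of the butylamino compound, an at least 8.3-fold lower number from compound 1 to compound 4 (0.92 log units; beyond the scatter), but that step is only a bound, as compound 1 is a limit of the assay: the limit of > 10000 nM in this assay, at which 1 of the 4 values shown sits.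

The compounds shown leave open how the number behaves with groups of intermediate size on this oxygen, such as methyl, propyl, butyl or tert-butyl, which would show where the rise from ethyl sets in. They also leave open what a smaller ring such as cyclopentyl, or a carboxylic acid in place of the ester, would give in this assay.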